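The source may hold more compounds than are shown below. What is called first, only, known or untested is meant among the compounds shown, and "the series" means these compounds.

Measured in a functional assay on HL-60 cells (Homo sapiens) for inhibition, read by CCK-8 assay, with a stated time of 48 h; on this read-out lower numbers stand for stronger inhibition and higher numbers for weaker inhibition:
- compound 1 `O=C(NCCNS(=O)(=O)c1ccc(-c2ccccc2OCc2cccc(O)c2)s1)Nc1cc(C(F)(F)F)cc(C(F)(F)F)c1`: 4000 nM
- compound 2 `Cc1ccc(-c2ccsc2S(=O)(=O)NCCNC(=O)Nc2ccc([N+](=O)[O-])cc2)c(Oc2ccc(O)c(O)c2)c1`: 3900 nM
- compound 3 `COc1ccc(NC(=O)NCCNS(=O)(=O)c2ccc(-c3ccccc3Oc3ccc([N+](=O)[O-])cc3)s2)cc1`: > 50000 nM (a limit of the assay, not a number)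

Compound 1 at 4000 nM and compound 2 at 3900 nM lie within the usual scatter of each other, so the two cannot be told apart. Compound 3 gives only a limit, > 50000 nM.

Compound 4 `O=C(NCCNS(=O)(=O)c1ccc(-c2ccccc2Oc2ccc([N+](=O)[O-])c([N+](=O)[O-])c2)s1)Nc1cc(C(F)(F)F)cc(C(F)(F)F)c1` has not yet been measured. It keeps the core of compound 1 and changes one group, with 3,4-dinitrophenyl in place of 3-hydroxybenzyl on an oxygen on an aromatic ring.

For the measured compounds named here, no pair of measured compounds differs by one change alone, so this step has no direct precedent. The main pointer is compound 3, which also carries a nitro-bearing phenyl on that oxygen but differs from compound 4 elsewhere. Compound 2 goes against a simple reading, since this compound also carries a nitro group and gives 3900 nM. A moderate rise in the number in this assay is therefore expected, meaning weaker inhibition, though the size is uncertain. The expected step is a 2.5-fold higher number from compound 1 to compound 4 (0.40 log units; beyond the scatter). For compound 4 the estimated value is 10000 nM, with an expected range of 2500 nM to 45000 nM.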

Compound 4, half-maximal inhibitory concentration: 1900 nM
Beside the measured number, compound 4's estimate is 5.3-fold (0.72 log units) above it; measured number below the stated range.
By their numbers in this assay, from the lowest: compound 4; then compounds 2 and 1 (each within the scatter of the next). At a limit, above all of these: compound 3.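

In this assay, for the compounds shown here, the change from 3-hydroxybenzyl to 3,4-dinitrophenyl on the oxygen gives the first direct comparison at this position, and the result is a 2.1-fold lower number from compound 1 to compound 4 (0.32 log units; beyond the scatter). This modest step shows that, with the rest of compound 1 unchanged, the position accepts a larger group that has no hydrogen-bond donor and more hydrogen-bond acceptors, while inhibition becomes somewhat stronger rather than weaker. The single pair shows that the change helps, but nothing shown here accounts for the difference.

Going by these compounds alone, it remains open whether both nitro groups are needed, as no compound here has a single nitro group on this ring with everything else as in compound 4. It is also unknown how this assay would respond to a plain phenyl group at this position, or to a phenyl ring carrying an amine or a carboxylic acid in place of the nitro groups.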